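From 4-methoxyphenyl to 3,4,5-trimethoxyphenyl in compound 3

The source may hold more compounds than are shown below. What is called first, only, known or untested is meant among the compounds shown, and "the series" means these compounds.

- compound 1 `COc1cc2ncnc(Nc3ccc(F)c(Cl)c3)c2cc1NC(=O)N/N=C/c1cccc(Br)c1` gives "not active" (no number reported)
- compound 2 `COc1ccc(/C=N/NC(=O)Nc2cc3c(Nc4ccc(F)c(Cl)c4)ncnc3cc2OC)cc1` gives 21300 nM

Going by the values given here, in a functional assay on HepG2 cells (Homo sapiens) for cytotoxicity, read by MTT assay, with a stated time of 72 h (a lower number here means a stronger inhibitor, a higher number a weaker inhibitor), compound 2, at 21300 nM, holds the only number available so far. The other measured compound, compound 1, was reported as "not active" (no number reported), without a number. Among the compounds with values here, with a single number there is no ranking to speak of, and no measured step between two compounds to serve as a guide.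

The next compound is compound 3 `COc1cc2ncnc(Nc3ccc(F)c(Cl)c3)c2cc1NC(=O)N/N=C/c1cc(OC)c(OC)c(OC)c1`, which keeps the shared core and the chain of compound 2 and changes only the aryl group. The change is 3,4,5-trimethoxyphenyl in place of 4-methoxyphenyl on a carbon with a double bond to nitrogen. In words, 3,4,5-trimethoxyphenyl takes the place of 4-methoxyphenyl on a carbon with a double bond to nitrogen.

With compound 2 at 21300 nM as the sole anchor, no change beyond the usual scatter is expected in this assay. The estimated step is a 1.2-fold lower number from compound 2 to compound 3 (0.07 log units; within the scatter). Like compound 1, compound 3 could also come back without a number. For compound 3 the expected value is 18000 nM, with an estimated range from 6000 nM to 50000 nM.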

Compound 3, half-maximal inhibitory concentration: 30100 nM
Compound 3: the middle estimate sits 1.7-fold (0.22 log units) below what was measured; the range from low to high includes it.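

In this assay, going by these compounds alone, this is the first step that can be read at this position, and a 1.4-fold higher number from compound 2 to compound 3 (0.15 log units; within the scatter) shows that the size of the change stays within the usual scatter. Within the data shown here, on the carbon with a double bond to nitrogen, 3,4,5-trimethoxyphenyl, with 12 heavy atoms and 3 hydrogen-bond acceptors, thus stands in place of 4-methoxyphenyl, with 8 heavy atoms and 1 hydrogen-bond acceptor, without a difference that can be told from scatter, and compound 3 returns a number just as compound 2 does, while no step to compound 1 can be read. Nothing available here accounts for this outcome.

The compounds shown carry only a bromo or methoxy substituents on this aryl group, so it remains open whether a 4-aminophenyl or a 4-carboxyphenyl on the same carbon would give a step beyond the scatter. Going by these compounds, it also remains open whether replacing the aryl group with a saturated ring such as cyclohexyl, or with a longer alkyl chain, would leave the number where it stands.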